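The compounds below may be only part of what the source reports. "The series", "measured", "known", "first", "only" and "open" are said of these compounds alone.

Compound 3 `Cc1cc(CNC(C)(C)C)c(O)c(Nc2nc3ccccc3[nH]2)c1` is examined in an ADME assay on CHO cells (Cricetulus griseus) for inhibition, read by MTT assay (on this read-out higher numbers stand for weaker inhibition and lower numbers for stronger inhibition), where compound 3 gives 33300 nM. Compound 1 `CC(C)(C)NCc1cc(Cl)cc(Nc2nc3ccccc3[nH]2)c1O` differs from it by chloro in place of methyl on an aromatic carbon. For compound 1 this assay reports only a limit, > 50000 nM. That exchange produced an at least 1.5-fold higher number from compound 3 to compound 1 (0.17 log units; that floor lies within the scatter). Compound 2 `Cc1cc(CNC(C)(C)C)c(O)c(Nc2nc3cc(F)c(F)cc3[nH]2)c1` rests on a different core, and how the two cores differ is not broken down here. In this assay compound 2 gives 16700 nM, and the gap to compound 3 sits within the usual scatter, so the two numbers are not told apart. Compound 4 `CC(C)(C)NCc1cc(Cl)cc(Nc2nc3cc(F)c(F)cc3[nH]2)c1O` is not yet measured; it differs from compound 2 by chloro in place of methyl on an aromatic carbon, the same change as made from compound 3 to compound 1, at the same place. Resting on an at least 1.5-fold higher number from compound 3 to compound 1 (0.17 log units; that floor lies within the scatter), the expected step is a 2.1-fold higher number from compound 2 to compound 4 (0.32 log units; beyond the scatter). Compound 4 is therefore estimated at 35000 nM, with a range from 15000 nM to 100000 nM. Given (the limit of > 50000 nM in this assay, at which 1 of the 3 values shown sits), compound 4 may also return only a limit instead of a number.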

Compound 4, half-maximal inhibitory concentration: 39700 nM
Estimate against measurement, compound 4: 1.1-fold (0.05 log units) below; measured number inside the range.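

In this assay, chloro in place of methyl on an aromatic carbon gives a 2.4-fold higher number from compound 2 to compound 4 (0.38 log units; beyond the scatter), a modest move towards weaker inhibition on the core of compound 2. Set beside the earlier case, this does not show that the size of the step carries over from one core to the other, and it shows no difference between the cores either: the same change on two cores in this assay, an at least 1.5-fold higher number (0.17 log units; that floor lies within the scatter) from compound 3 to compound 1 and a 2.4-fold higher number (0.38 log units; beyond the scatter) from compound 2 to compound 4; the limit leaves it open whether they differ. Within the data shown here, the earlier step is known only as a floor, since the value of compound 1 is a limit of the assay, so the two cases offer no more than a pair of steps pointing the same way, one of them not firmly read: the limit of > 50000 nM in this assay, at which 1 of the 4 values shown sits.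

The compounds shown leave open whether a bromo or a methoxy group at the same place would follow chloro. They also leave open whether the exchange would hold with a dimethylamino group in place of the tert-butylamino part of the ((tert-butyl)amino)methyl group.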